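Aryl thioether variation on a cinnamamide series

The source may report more compounds than this note shows. Statements on the series, on what has been measured and on what is new or still open speak of the compounds shown alone.

Measured compounds:
compound 1 `Nc1ccccc1NC(=O)/C=C/c1ccc(CSc2ccc(F)cc2)cc1`, 18.3%
compound 2 `Cc1cc(C)cc(SCc2ccc(/C=C/C(=O)Nc3ccccc3N)cc2)c1`, 8.61%
compound 3 `Nc1ccccc1NC(=O)/C=C/c1ccc(CSc2cccc(F)c2)cc1`, 8.56%

In a functional assay on SMMC-7721 cells (Homo sapiens) for inhibition, read by CCK-8 assay, with a stated time of 72 h, tested at 2 uM (on this read-out lower numbers stand for less inhibition of growth and higher numbers for more inhibition of growth at the one concentration tested), compound 1 gives 18.3%, compound 2 gives 8.61% and compound 3 gives 8.56%. Compound 3 sits at the low end of the three numbers, yet the gaps a number 9.7 percentage points lower from compound 1 to compound 3 (within the scatter) and a number 0.1 percentage points lower from compound 2 to compound 3 (within the scatter) are both within the scatter, so the three read alike.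

Compound 4 `CC(C)(C)c1ccc(SCc2ccc(/C=C/C(=O)Nc3ccccc3N)cc2)cc1` differs from compound 3 by 4-(tert-butyl)phenyl in place of 3-fluorophenyl on a sulfur. Every measured step here changes the aryl group on the same sulfur: a number 9.7 percentage points lower from compound 1 to compound 2 (within the scatter), a number 9.7 percentage points lower from compound 1 to compound 3 (within the scatter) and a number 0.1 percentage points lower from compound 2 to compound 3 (within the scatter), none beyond the scatter. The expected step is therefore none beyond the scatter, a number 2.4 percentage points higher from compound 3 to compound 4 (within the scatter). Compound 4 is estimated at 11%, in a range from 3% to 22%.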

Compound 4, percent growth inhibition at one concentration: 18.3%
Beside the measured number, compound 4's estimate is 7.3 percentage points below it; measured number inside the range.
By their numbers in this assay, from the lowest: compounds 3, 2, 1 and 4 (each within the scatter of the next).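

With 4-(tert-butyl)phenyl on the sulfur, the reading in this assay stays within the scatter of all three earlier aryl groups (a number 9.7 percentage points higher from compound 3 to compound 4 (within the scatter)) and (a number 9.7 percentage points higher from compound 2 to compound 4 (within the scatter)) and (no change at the digits printed from compound 1 to compound 4 (within the scatter)). This position therefore accepts an all-carbon 4-(tert-butyl)phenyl group without a step beyond the scatter, and the four aryl groups shown do not separate. Nothing available explains this reading.

From the compounds shown here alone, it remains open whether an aryl group carrying an amine or a carboxylic acid would read differently at this sulfur. The same question stands for a pyridine ring in place of the phenyl ring.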